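The compounds below may be only part of what the source reports. "The series", "measured", "known", "first", "only" and "open" are said of these compounds alone.

Measured compounds in the series:
compound 1 `O=c1cc(-c2ccc(-c3ccccc3)cc2)oc2cc(OCCCCCCCCN3CCCC3)ccc12`: 71.9%
compound 2 `O=c1cc(-c2ccccc2O)oc2cc(OCCCCCCCCN3CCCC3)ccc12`: 60.6%
compound 3 `COc1ccccc1-c1cc(=O)c2ccc(OCCCCCCCCN3CCCC3)cc2o1`: 24.3%

In an ADME assay on HepG2 cells (Homo sapiens) for cytotoxicity, read by MTT assay, with a stated time of 48 h, tested at 10 uM (a lower number here means a weaker effect, a higher number a stronger effect of the compound at the concentration tested), compound 3 stands lowest of the three numbers: compound 2 sits nearer, and the gap to it is a number 36.3 percentage points lower from compound 2 to compound 3 (beyond the scatter); compound 1 sits furthest, with a gap of a number 47.6 percentage points lower from compound 1 to compound 3 (beyond the scatter). Both gaps lie beyond the scatter, so compound 3 is the weakest of the measured set in this assay.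

Compound 4 `COc1cc(-c2cc(=O)c3ccc(OCCCCCCCCN4CCCC4)cc3o2)cc(OC)c1OC` is not yet measured. Relative to compound 3 its change is 3,4,5-trimethoxyphenyl in place of 2-methoxyphenyl on an aromatic carbon.

Going by the values given here, two measured steps bear on this change, both replacing the aryl group on the shared core: a number 47.6 percentage points lower from compound 1 to compound 3 (beyond the scatter) and a number 11.3 percentage points lower from compound 1 to compound 2 (beyond the scatter). A third, a number 36.3 percentage points lower from compound 2 to compound 3 (beyond the scatter), shows that adding a single methyl on a ring oxygen alone moved the number by a large amount. Among the compounds with values here, no measured pair adds methoxy groups beyond one, so the direction for compound 4 rests on analogy only: aryl changes have produced modest to large shifts, and compound 3 already sits at the low end, leaving more room upward than downward. A small to modest rise is expected, with wide uncertainty.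

Compound 4 is estimated at 35% (range 15% to 60%). The expected step is a number 10.7 percentage points higher from compound 3 to compound 4 (beyond the scatter).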

Compound 4, a percentage reported as inhibition, at one concentration (the size of the read-out at that concentration, not a potency): 41.4%
The estimate for compound 4 lay 6.4 percentage points below the measured number; measured number inside the range.
By their numbers in this assay, from the lowest: compound 3; then compound 4; then compound 2; then compound 1.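

In this assay, 3,4,5-trimethoxyphenyl in place of 2-methoxyphenyl on the aromatic carbon next to the ring oxygen gives a number 17.1 percentage points higher from compound 3 to compound 4 (beyond the scatter), so an aryl group carrying methoxy groups need not sit at the bottom of the series, and the methoxy-bearing aryl groups compared here differ from each other beyond the scatter. The same replacement does not reach the other two aryl groups: a number 19.2 percentage points lower from compound 2 to compound 4 (beyond the scatter) and a number 30.5 percentage points lower from compound 1 to compound 4 (beyond the scatter), which places the 3,4,5-trimethoxyphenyl group in the middle of the series and leaves 4-phenylphenyl with the highest number of the four. No supporting measurement bears on this result, so the shift stands as an observation without an explanation.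

This single change alters the number of methoxy groups and their places together, so a 4-methoxyphenyl or 3,5-dimethoxyphenyl group would be needed to separate the two. Also open, on these data alone, is whether 3,4,5-trihydroxyphenyl would relate to compound 4 as the hydroxyl relates to the methoxy group in a number 36.3 percentage points lower from compound 2 to compound 3 (beyond the scatter), or whether an amine or a carboxylic acid on this aryl ring would shift the number at all.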